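A Sulfoxide Variant of the Pentylsulfanyl Analogue

A few compounds are considered here, and "the series" means these few. Any claim that something is new, unique, unknown or untested is made for them only; others in the source may bear on it.

Compound 1 `Nc1nc(SCc2ccccc2)nc2c1nc(O)n2Cc1ccccc1`: 0.1 uM
Compound 2 `CCSc1nc(N)c2nc(O)n(Cc3ccccc3)c2n1`: 0.1 uM
Compound 3 `CCCCCSc1nc(N)c2nc(O)n(Cc3ccccc3)c2n1`: 10 uM

In a functional assay (spleen, spleen) for activation, with Mus musculus as the target (a lower number here means that less compound is needed, a higher number that more compound is needed for the effect), compound 3 gives the highest of the three numbers; the step of a 100-fold higher number from compound 1 to compound 3 (2.00 log units; beyond the scatter) and the step of a 100-fold higher number from compound 2 to compound 3 (2.00 log units; beyond the scatter) both place it far above the other two. Compound 4 `CCCC[S+]([O-])c1nc(N)c2nc(O)n(Cc3ccccc3)c2n1` differs from compound 3 by a group of 6 heavy atoms (4 carbon, 1 oxygen, 1 sulfur; no ring) in place of a group of 6 heavy atoms (5 carbon, 1 sulfur; no ring), on an aromatic carbon. Within the data shown here, no measured step covers the oxygen that enters; only the two chain-length steps, both large, bear on this change, and the carbon count of the chain falls from five to four. The step of a 3.3-fold lower number from compound 3 to compound 4 (0.52 log units; beyond the scatter) is therefore expected to give a modestly lower number, with wide uncertainty. Compound 4 is expected to give 3 uM in this assay, in the range 0.3 uM to 30 uM.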

Compound 4, minimum effective concentration: 0.01 uM
Compound 4: middle estimate off by 300-fold (2.48 log units), on the high side; the measured number lies below the stated range.
By their numbers in this assay, from the lowest: compound 4; then compounds 1 and 2 (each within the scatter of the next); then compound 3.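

In this assay this aromatic carbon proves able to do more than the chain-length steps showed: the sulfoxide brings a 1000-fold lower number from compound 3 to compound 4 (3.00 log units; beyond the scatter) and so runs opposite to the loss seen with the pentylsulfanyl group. It also passes both earlier compounds with the lower numbers, giving a 10-fold lower number from compound 2 to compound 4 (1.00 log units; beyond the scatter) and a 10-fold lower number from compound 1 to compound 4 (1.00 log units; beyond the scatter) as the two remaining steps. Nothing available explains this result.

Compound 4 differs from compound 3 in both chain length and the added oxygen, and their shares cannot be told apart. Going by these compounds, a butylsulfanyl group, or an ethyl chain on the same sulfoxide, remains open.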